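This account rests on a few compounds, and the source may have more. Where it says the series, first, only, none or still open, it means among the compounds named here.

Measured compounds:
- compound 1, `O=c1cc(-c2ccccc2)oc2cc(N3COc4c(cccc4[N+](=O)[O-])C3)ccc12`: 15.7%
- compound 2, `O=c1cc(-c2ccccc2)oc2ccc(N3COc4c(Br)cc(Br)cc4C3)cc12`: 34.5%
- compound 3, `Cc1cccc2c1OCN(c1ccc3oc(-c4ccccc4)cc(=O)c3c1)C2`: 85.1%

In a functional assay on MCF7 cells (Homo sapiens) for inhibition, read by MTT assay, with a stated time of 48 h, tested at 60 ug/mL (a lower number here means less inhibition of growth, a higher number more inhibition of growth at the concentration tested), compound 1 gives 15.7%, the lowest of the three numbers. Compound 2 gives 34.5%, a gap beyond the scatter. Compound 3 gives 85.1%, the furthest from compound 1 and also beyond the scatter. Among the compounds with values here, no two measured compounds differ in just one place, so no single-change step is available as a direct guide.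

Compound 4, `Cc1cccc2c1OCN(c1ccc3c(=O)cc(-c4ccccc4)oc3c1)C2`, is not yet measured. It differs from compound 1 by methyl in place of nitro on an aromatic carbon. Within the data shown here, with no measured step to lean on, the only orientation is that compound 1 sits at the bottom of the range and that the other two numbers lie well above it. The step from compound 1 to compound 4 is expected to be upward and beyond the scatter, at a number 34.3 percentage points higher from compound 1 to compound 4 (beyond the scatter). Compound 4 is therefore expected to give about 50% in this assay, within 20% to 80%.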

Compound 4, percent growth inhibition at one concentration: 66.6%
Beside the measured number, compound 4's estimate is 16.6 percentage points below it; the measured number falls inside the stated range.
By their numbers in this assay, from the lowest: compound 1; then compound 2; then compound 4; then compound 3.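

In this assay, within the data shown here, methyl in place of nitro on an aromatic carbon gives a number 50.9 percentage points higher from compound 1 to compound 4 (beyond the scatter) and is the first single-change step. Among these compounds, it shows that the group at this place, on the six-membered aromatic ring of carbon only, can by itself move growth inhibition by a large amount, which the earlier compounds, none a single change from another, could not show. No measured property is available to account for this step.

From the compounds shown here alone, it remains open whether the step follows from gaining methyl or from losing nitro; an amine, a methoxy group or plain hydrogen at the same aromatic carbon would help separate the two. Going by these compounds, the step also rests on a single pair at one concentration, so its size on other substitution patterns of the core remains unknown.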